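Trifluoromethoxy for trifluoromethyl on the aryl of compound 1

The source may report more compounds than this note shows. Statements on the series, on what has been measured and on what is new or still open speak of the compounds shown alone.

Going by the values given here, compound 1 `C[C@]1(O)C[C@@](c2cccc(C(F)(F)F)c2)([C@H](O)c2ccccn2)C1` carries the highest number of the three measured so far: in an assay on HEK293 cells for antagonist activity at transient receptor potential cation channel subfamily V member 3 (Homo sapiens), read by FLIPR and calcium flux (on this read-out higher numbers stand for weaker inhibition and lower numbers for stronger inhibition), compound 1 gives 300 nM. Compound 2 `O[C@]1(c2ccccn2)CC[C@@H](c2ccc(C(F)(F)F)cc2)C1` gives 130 nM in this assay, and compound 3 `O[C@H](c1ccccn1)[C@]1(c2ccnc(C(F)(F)F)c2)C[C@H](O)C1` gives 60 nM; both gaps to compound 1 lie beyond the scatter, so compound 1 is the weakest inhibitor of the measured set. Compound 4 `C[C@]1(O)C[C@@](c2cccc(OC(F)(F)F)c2)([C@H](O)c2ccccn2)C1` has not been measured. It differs from compound 1 in one place: trifluoromethoxy in place of trifluoromethyl on an aromatic carbon. Among the compounds with values here, no measured pair isolates this change, so there is no step to lean on. The expected step from compound 1 to compound 4 is a 1.2-fold lower number from compound 1 to compound 4 (0.06 log units; within the scatter), with no direction favoured beyond the scatter. Compound 4 is therefore estimated at 260 nM, between 100 nM and 700 nM.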

Compound 4, antagonist equilibrium constant: 280 nM
Compound 4: the middle estimate sits 1.1-fold (0.03 log units) below what was measured, and the stated range covers the measured number.
By their numbers in this assay, from the lowest: compound 3; then compound 2; then compounds 4 and 1 (each within the scatter of the next).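

Going by these compounds alone, with a 1.1-fold lower number from compound 1 to compound 4 (0.03 log units; within the scatter), this is the first step that isolates a single change, and it offers no basis for separating trifluoromethoxy from trifluoromethyl on this aromatic carbon, meta to a large group. The added oxygen, counted as a hydrogen-bond acceptor, leaves the read-out unresolved here. No available data bear on why the two groups read alike.

Still open, going by these compounds, is whether a nitrile or an amine on this same carbon would move the number beyond the scatter. Also open, on these data alone, is whether the swap reads the same on the cores of compound 2 and compound 3.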